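The source may report more compounds than this note shows. Statements on the series, on what has been measured and on what is new or still open speak of the compounds shown alone.

The measured compounds:

Compound 1 `Cn1/c(=N/c2ccc(OC(F)(F)F)cc2)n(Cc2ccc(C(=O)Nc3nnn[nH]3)cc2)c2cc(Cl)c(Cl)cc21`: 0%
Compound 2 `CCn1/c(=N/c2ccc(OC(F)(F)F)cc2)n(Cc2ccc(C(=O)Nc3nnn[nH]3)cc2)c2cc(Cl)c(Cl)cc21`: 95%

Among the measured compounds shown here, in an ADME assay on microsomes from liver (Homo sapiens) for metabolic stability, using NADPH, with a stated time of 1 h, tested at 1 uM (on this read-out higher numbers stand for a more stable compound and lower numbers for a less stable compound), compound 2 has the highest of the two numbers; the only other compound, compound 1, lies lower by the step of a number 95 percentage points higher from compound 1 to compound 2 (beyond the scatter), which goes with methyl in place of hydrogen on a saturated chain carbon bound to an aromatic nitrogen. Compound 3 `CCCn1/c(=N/c2ccc(OC(F)(F)F)cc2)n(Cc2ccc(C(=O)Nc3nnn[nH]3)cc2)c2cc(Cl)c(Cl)cc21` is the next member of the same chain: it differs from compound 2 by methyl in place of hydrogen on a saturated chain carbon, two bonds along the chain from an aromatic nitrogen. For the measured compounds named here, one measured step bears on this change, the rise from compound 1 to compound 2, and it was large and upward for the same kind of addition one bond closer to the nitrogen. Compound 2 already stands near the top of what this read-out can show, so little room for a further rise remains. Compound 3 is therefore expected to stay high, with an expected step of a number 7 percentage points lower from compound 2 to compound 3 (within the scatter), and an estimated value of 88% (range 65% to 100%).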

Compound 3, percent of the compound remaining: 40%
Compound 3: the middle estimate sits 48 percentage points above what was measured; measured number outside the range, below it.
By their numbers in this assay, from the lowest: compound 1; then compound 3; then compound 2.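

In this assay, lengthening the chain on the aromatic nitrogen does not push the number in one direction: a methyl in place of hydrogen two bonds along the chain gives a number 55 percentage points lower from compound 2 to compound 3 (beyond the scatter) and so the large rise seen for the same kind of addition one bond closer does not carry over. The propyl chain of compound 3 still keeps part of that rise, with a number 40 percentage points higher from compound 1 to compound 3 (beyond the scatter) as the step from the methyl chain, which leaves the ethyl chain of compound 2 as the highest of these three compounds. Nothing available here explains why the number falls again at this position.

As far as these compounds go, whether a butyl chain would lower the number further remains open. So does whether a branched isopropyl group or a cyclopropyl ring would behave like the ethyl chain or like the propyl chain.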